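The source may hold more compounds than are shown below. What is called first, only, known or untested is meant among the compounds shown, and "the series" means these compounds.

Measured in a functional assay on HepG2 cells (Homo sapiens) for cytotoxicity, read by spectrophotometry, with a stated time of 72 h; on this read-out lower numbers stand for stronger inhibition and higher numbers for weaker inhibition:
compound 1 `COc1cc(-n2c(-c3ccc(OC(F)(F)F)cc3)cccc2=O)cc(OC)c1OC` gives 1960 nM
compound 2 `COc1ccc(-n2c(-c3cc(OC)c(OC)c(OC)c3)cccc2=O)cc1OCc1ccccc1` gives 3040 nM
compound 3 `COc1ccc(-n2c(-c3cc(OC)c(OC)c(OC)c3)cccc2=O)cc1O` gives 1220 nM

Compound 3 at 1220 nM lies within the scatter of compound 1 but not of compound 2. Going on to compound 4 `COc1cc(-c2cccc(=O)n2-c2ccc([N+](=O)[O-])cc2)cc(OC)c1OC` means 4-nitrophenyl in place of 3-hydroxy-4-methoxyphenyl on an aromatic nitrogen that is, 4-nitrophenyl in place of 3-hydroxy-4-methoxyphenyl on an aromatic nitrogen. Going by the values given here, only one measured step touches this group, namely a 2.5-fold lower number from compound 2 to compound 3 (0.40 log units; beyond the scatter) and it was modest. Among the compounds with values here, no measured step replaces the whole group, so a modest move towards a higher number is expected in this assay with wide uncertainty. The expected step is a 2.5-fold higher number from compound 3 to compound 4 (0.39 log units; beyond the scatter) by this estimate. For compound 4 the estimated value is 3000 nM with an expected range from 900 nM to 10000 nM in all.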

Compound 4, half-maximal inhibitory concentration: 941 nM
Estimate against measurement, compound 4: 3.2-fold (0.50 log units) above, and the stated range covers the measured number.
By their numbers in this assay, from the lowest: compounds 4, 3, 1 and 2 (each within the scatter of the next, the first and the last beyond it).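

In this assay, replacing the whole group on the aromatic nitrogen with 4-nitrophenyl gives a 1.3-fold lower number from compound 3 to compound 4 (0.11 log units; within the scatter) and so leaves the number within the scatter. The earlier step had changed only a substituent on an oxygen of this ring, whereas this one exchanges the entire ring substitution, and the entering group carries no hydrogen-bond donor. Nothing available explains this outcome.

Going by these compounds, whether an amine or a carboxylic acid in place of the nitro group would also leave the number unchanged remains open. So does the effect of moving the nitro group elsewhere on this ring.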